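The source may hold more compounds than are shown below. What is called first, only, known or untested is meant among the compounds shown, and "the series" means these compounds.

Measured in a functional assay on A549 cells (Homo sapiens) for antiproliferative activity, read by MTT assay; on this read-out lower numbers stand for stronger inhibition and higher numbers for weaker inhibition:
compound 1 `Cn1c(=O)c(=O)n(C2CCCC2)c2nc(N/N=C/c3ccc(F)c(Cl)c3)ncc21`: 9410 nM
compound 2 `Cn1c(=O)c(=O)n(C2CCCC2)c2nc(N/N=C/c3ccc(S(C)(=O)=O)cc3)ncc21`: 84500 nM
compound 3 `Cn1c(=O)c(=O)n(C2CCCC2)c2nc(N/N=C/c3ccc(O)c(F)c3)ncc21`: 97800 nM

Compound 3 stands at the high end of these numbers, together with compound 2, and the two cannot be told apart: a 1.2-fold higher number from compound 2 to compound 3 (0.06 log units; within the scatter). Compound 4 `Cn1c(=O)c(=O)n(C2CCCC2)c2nc(N/N=C/c3ccc(C(F)(F)F)cc3)ncc21` carries 4-(trifluoromethyl)phenyl in place of 3-fluoro-4-hydroxyphenyl on a carbon with a double bond to nitrogen. Two measured steps away from the 3-chloro-4-fluorophenyl group are similar in size: a 10-fold higher number from compound 1 to compound 3 (1.02 log units; beyond the scatter) and a 9.0-fold higher number from compound 1 to compound 2 (0.95 log units; beyond the scatter). The groups in compound 2 and compound 3 both contain oxygen, whereas the group in compound 1, at 9410 nM, contains none, and neither does the entering group. On that resemblance alone, a lower number is expected in this assay, though probably not the full way back to compound 1, since three compounds cannot show how far the resemblance holds. The expected change is a 3.9-fold lower number from compound 3 to compound 4 (0.59 log units; beyond the scatter). Compound 4 is estimated at 25000 nM, with a range from 8000 nM to 90000 nM.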

Compound 4, half-maximal inhibitory concentration: 40600 nM
The estimate for compound 4 lay 1.6-fold (0.21 log units) below the measured number, and the stated range covers the measured number.
By their numbers in this assay, from the lowest: compound 1; then compound 4; then compounds 2 and 3 (each within the scatter of the next).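

In this assay, among these compounds, the place on a carbon with a double bond to nitrogen now separates groups that the earlier compounds had left level: with a 2.4-fold lower number from compound 3 to compound 4 (0.38 log units; beyond the scatter) and a 2.1-fold lower number from compound 2 to compound 4 (0.32 log units; beyond the scatter), 4-(trifluoromethyl)phenyl stands apart from both oxygen-bearing groups, yet with a 4.3-fold higher number from compound 1 to compound 4 (0.63 log units; beyond the scatter), it falls short of 3-chloro-4-fluorophenyl. A group without oxygen therefore goes with a lower number in all four compounds, but compound 1 and compound 4, both without oxygen, still differ beyond the scatter, so the absence of oxygen does not set the number by itself. Nothing measured here explains these differences.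

The compounds shown leave open where a plain phenyl, a 4-chlorophenyl or a 3-chlorophenyl would fall on this scale. They also leave open how a phenyl carrying an amine or a carboxylic acid would read out in this assay.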